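Adding a chloro group to compound 2

This account rests on a few compounds, and the source may have more. Where it says the series, first, only, none or still open, it means among the compounds named here.

Compound 1 `O=C(CCCCC(S)CCS)NO` gives 43.7% here
Compound 2 `CC(=O)SCCC(CCCCC(=O)Nc1ccccc1)SC(C)=O` gives 44.8% here

Both compounds were tested in a functional assay on NCI-H460 cells (Homo sapiens) for inhibition, read by MTT assay, with a stated time of 24 h, tested at 100 ug/mL (a higher number here means more inhibition of growth at the concentration tested, a lower number less inhibition of growth), and each result is a single reading at one concentration. Compound 2 at 44.8% stands level with compound 1 at 43.7%. The gap between these two values lies within the usual scatter of repeated measurements.

The next compound, compound 3 `CC(=O)SCCC(CCCCC(=O)Nc1cccc(Cl)c1)SC(C)=O`, keeps the structure of compound 2 with one change, chloro in place of hydrogen on an aromatic carbon. The new group sits meta to a large group, and the same difference can be read as phenyl to 3-chlorophenyl.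

Within the data shown here, no two measured compounds differ in only one place, so the data show no earlier step of this kind. The expectation therefore starts from compound 2 at 44.8% and allows a wide range. Expected here is a number 2.2 percentage points higher from compound 2 to compound 3 (within the scatter), a small rise that would stay within the scatter. For compound 3 the estimated value is 47%, with an expected range from 33% to 61% in this measurement.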

Compound 3, percent growth inhibition at one concentration: 42.8%
The estimate for compound 3 lay 4.2 percentage points above the measured number; measured number inside the range.
By their numbers in this assay, from the lowest: compounds 3, 1 and 2 (each within the scatter of the next).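

Among these compounds, the step of a number 2 percentage points lower from compound 2 to compound 3 (within the scatter) in this assay is the first change in this set that can be read on its own, since compound 1 and compound 2 differ in more than one place. It shows that, on this aromatic carbon, meta to a large group, replacing hydrogen with a single chloro leaves a difference that cannot be told apart from the ordinary spread of repeated readings at this one concentration. No measurement of any property of the two compounds bears on this result, so the data offer no explanation for it.

Still open is whether chloro would read the same on other carbons of the ring, since only this one place is shown. From the compounds shown here alone, it is also open whether a different group on this same carbon, such as an amine, a carboxylic acid or a methoxy group, would move the number beyond that spread.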